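Second Chloro on the Aryl Thioether of Compound 1

The compounds below may be only part of what the source reports. "The series", "measured", "known", "first", "only" and "open" are said of these compounds alone.

Compound 1 `C#CCNC1CCc2c(SCCc3ccc(Cl)cc3)cccc21` gives 10800 nM in an assay on isolated protein for inhibition of Amine oxidase [flavin-containing] B (Homo sapiens) (a lower number here means a stronger inhibitor, a higher number a weaker inhibitor), the higher of the two numbers reported, while compound 2 `C#CCNC1CCc2c(SCc3ccc(Cl)cc3Cl)cccc21` gives 3760 nM, a gap beyond the usual scatter. Compound 3 `C#CCNC1CCc2c(SCc3cccc(Br)c3)cccc21` reaches only the assay limit of > 100000 nM in this assay, and the limit of > 100000 nM in this assay, at which 1 of the 3 values shown sits, is all that is recorded for it. Compound 4 `C#CCNC1CCc2c(SCCc3ccc(Cl)c(Cl)c3)cccc21` differs from compound 1 by a single change, (chloro in place of hydrogen on an aromatic carbon), so that the 4-chlorophenyl becomes a 3,4-dichlorophenyl. Among the compounds with values here, no measured pair shows this exact change, so the expected step from compound 1 to compound 4 in this assay, a 2.2-fold lower number from compound 1 to compound 4 (0.33 log units; beyond the scatter), is a modest one toward a lower number, a guess rather than a pattern. On that basis compound 4 is estimated at 5000 nM, between 1500 nM and 20000 nM.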

Compound 4, half-maximal inhibitory concentration: 3850 nM
The estimate for compound 4 lay 1.3-fold (0.11 log units) above the measured number; low and high end bracket the measured number.
By their numbers in this assay, from the lowest: compounds 2 and 4 (each within the scatter of the next); then compound 1. At a limit, above all of these: compound 3.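

The change from 4-chlorophenyl to 3,4-dichlorophenyl gives a 2.8-fold lower number from compound 1 to compound 4 (0.45 log units; beyond the scatter) in this assay, the only step shown between compounds that differ in one place. It shows that chloro in place of hydrogen on this aromatic carbon, ortho to a chloro group, moves the number beyond the scatter. Nothing measured here gives a reason for this step.

Still open, as far as these compounds go, is whether a fluoro, a methyl or a methoxy group on this carbon would move the number the same way. Also open, from the compounds shown here alone, is whether the second chloro would have a similar effect on a longer chain.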